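This account rests on a few compounds, and the source may have more. Where it says the series, first, only, none or still open, it means among the compounds named here.

Three compounds built on two closely related cores were tested in a functional assay on trachea (Cavia porcellus); on this read-out lower numbers stand for stronger inhibition and higher numbers for weaker inhibition. Compound 1 `CCN1CC[C@@]2(OC)OC(N)=C(C#N)[C@@H](c3ccc4ccccc4c3)[C@@H]2C1` gives 28300 nM in this assay. Compound 2 `CCCN1CC[C@@]2(OC)OC(N)=C(C#N)[C@@H](c3ccc4ccccc4c3)[C@@H]2C1` differs from compound 1 by methyl in place of hydrogen on a saturated chain carbon, two bonds along the chain from an amine nitrogen in a ring. In this assay compound 2 gives 37100 nM. The step of a 1.3-fold higher number from compound 1 to compound 2 (0.12 log units; within the scatter) is therefore small. Compound 3 `CO[C@@]12CCN(C)C[C@H]1[C@H](c1ccc(Br)cc1)C(C#N)=C(N)O2` carries a different core; how the core of compound 3 differs from the core of compound 1 is not broken down here. In this assay compound 3 gives 7900 nM, the lowest number of the three measured, and its gaps to compound 1 and to compound 2 both lie beyond the scatter.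

Compound 4 `CCN1CC[C@@]2(OC)OC(N)=C(C#N)[C@@H](c3ccc(Br)cc3)[C@@H]2C1` has not yet been measured in this assay. It differs from compound 3 by methyl in place of hydrogen on a saturated chain carbon bound to an amine nitrogen in a ring. For the measured compounds named here, this is the same kind of change as the one from compound 1 to compound 2, though not the same: there the carbon stands two bonds along the chain from an amine nitrogen in a ring, whereas here the carbon is bound to that amine nitrogen. Because the measured step of a 1.3-fold higher number from compound 1 to compound 2 (0.12 log units; within the scatter) stayed within the scatter, the expected step for this related change is a 1.2-fold higher number from compound 3 to compound 4 (0.08 log units; within the scatter), meaning little movement. The estimate for compound 4 in this assay is 9500 nM, with a likely range from 4000 nM to 25000 nM.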

Compound 4, half-maximal inhibitory concentration: 13200 nM
The estimate for compound 4 lay 1.4-fold (0.14 log units) below the measured number; the range from low to high includes it.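

In this assay, placing a methyl on the core of compound 3 gives a 1.7-fold higher number from compound 3 to compound 4 (0.22 log units; within the scatter), so this small addition does not separate the two compounds on this read-out. Set beside the earlier case, the step carries over from one core to the other without a difference that can be told from noise: the same change on two cores in this assay, a 1.3-fold higher number (0.12 log units; within the scatter) from compound 1 to compound 2 and a 1.7-fold higher number (0.22 log units; within the scatter) from compound 3 to compound 4, 1.3-fold (0.11 log units) apart, within the scatter of two such steps What this shows is limited but useful: on both cores shown, lengthening the chain on the ring amine nitrogen by one carbon leaves the number about where it was, so the earlier step was a fair guide here. It does not show that the change has a real direction, even though both printed steps point to higher numbers, as each one lies within the scatter, and two cores say nothing firm about a third core or about a larger change.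

The compounds shown stop at a propyl chain in this place, so it remains open whether a butyl chain, a benzyl group or a plain hydrogen on that nitrogen would produce a step beyond the scatter. As far as these compounds go, it also remains open whether such a step would be the same size on both cores.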